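Chloro to Fluoro on the Sulfur-Bound Benzyl Group

This account rests on a few compounds, and the source may have more. Where it says the series, first, only, none or still open, it means among the compounds named here.

Compound 1 `CC1=C(C(=O)Nc2ccc([N+](=O)[O-])cc2)C(c2cccc([N+](=O)[O-])c2)N=C(SCc2cccc(Cl)c2)N1` and compound 2 `CC1=C(C(=O)Nc2ccc([N+](=O)[O-])cc2)C(c2cccc([N+](=O)[O-])c2)N=C(SCc2ccc(Cl)cc2)N1` share one core and differ only in where the chloro sits on the phenyl that hangs from the sulfur. In a functional assay on the whole organism (artery, strain albino) with Rattus norvegicus as the target, with a stated time of 120 min, at a dose of 10 mg/kg by the oral route (a higher number here means more inhibition at the dose given (going by the name of the read-out), a lower number less inhibition), compound 1 gives 12.4%, and compound 2 gives 12.4%. Going by the values given here, the step of no change at the digits printed from compound 1 to compound 2 (within the scatter) therefore left the read-out where it was, and compound 2 stands level with compound 1 at the digits recorded, with no other measured compound to set it against.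

Compound 3 `CC1=C(C(=O)Nc2ccc([N+](=O)[O-])cc2)C(c2cccc([N+](=O)[O-])c2)N=C(SCc2ccc(F)cc2)N1` has not yet been measured. It differs from compound 2 by fluoro in place of chloro on an aromatic carbon; read one bond further out, this is 4-chlorobenzyl to 4-fluorobenzyl. Among the compounds with values here, no measured step exchanges one halogen for another, and the single measured step, which only moved the chloro around the ring, was flat. Nothing in the data argues for a shift in either direction, so the step of a number 0.4 percentage points lower from compound 2 to compound 3 (within the scatter) is expected to stay within the scatter. Compound 3 is estimated at 12% in this assay, with a range from 2% to 25%.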

Compound 3, a percentage reported as inhibition, in the whole organism at one dose (the size of the read-out at that dose, not a potency): 13.4%
Estimate against measurement, compound 3: 1.4 percentage points below; the range from low to high includes it.
By their numbers in this assay, from the lowest: compounds 1, 2 and 3 (each within the scatter of the next).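

In this assay, a number 1 percentage points higher from compound 2 to compound 3 (within the scatter) shows that replacing the halogen itself, as 4-chlorobenzyl gives way to 4-fluorobenzyl, does not separate the two compounds, whereas the earlier step only moved the chloro around the ring. The step of a number 1 percentage points higher from compound 1 to compound 3 (within the scatter), which alters both the halogen and its place on the ring, is also within the scatter, so the three compounds cannot be put in any order and neither the identity of these two halogens nor the chloro's place has a readable effect on this measure of inhibition at the dose given. No available measurement offers an explanation for this result.

As far as these compounds go, all three compounds carry a single halogen on the benzyl ring, so it remains open whether the read-out would respond to a different kind of group there, such as a methoxy group, an amine or a carboxylic acid, or to a longer chain between the sulfur and the ring. The rest of the shared core is the same throughout, which leaves open what the nitro groups contribute and whether a change there would move the read-out beyond the scatter.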